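Amine variation on the shared core: an inactive set

The compounds below may be only part of what the source reports. "The series", "measured", "known", "first", "only" and "open" are said of these compounds alone.

Compound 3 `O=C(c1cc(Cc2n[nH]c(=O)c3ccccc23)ccc1F)N1CCc2nc(N3CCCCC3)ncc2C1` stands at the ceiling of the numbers shown. In a functional assay on MDA-MB-231 cells (Homo sapiens) for inhibition, read by MTT assay, with a stated time of 48 h (a higher number here means a weaker inhibitor, a lower number a stronger inhibitor), compound 3 gives > 200000 nM, which is a limit of the assay and not a number. Compound 1 `CN1CCN(c2ncc3c(n2)CCN(C(=O)c2cc(Cc4n[nH]c(=O)c5ccccc45)ccc2F)C3)CC1` carries 4-methylpiperazin-1-yl on the same aromatic carbon; in this assay compound 1 gives > 200000 nM, again only a limit. Compound 2 `O=C(c1cc(Cc2n[nH]c(=O)c3ccccc23)ccc1F)N1CCc2nc(N3CCCC3)ncc2C1` carries pyrrolidin-1-yl there; compound 2 gives > 200000 nM, also a limit. The three exchanges of the amine are therefore not readable: a step that the two limits leave unreadable from compound 1 to compound 2, a step that the two limits leave unreadable from compound 1 to compound 3 and a step that the two limits leave unreadable from compound 2 to compound 3. What holds them together is the limit of > 200000 nM in this assay, at which 3 of the 3 values shown sit.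

Compound 4 `CCCN(CCC)c1ncc2c(n1)CCN(C(=O)c1cc(Cc3n[nH]c(=O)c4ccccc34)ccc1F)C2` is the next member of this series, differing from compound 3 by dipropylamino in place of piperidin-1-yl on an aromatic carbon. The three measured steps bear on it, since each swaps the amine on the same aromatic carbon, but each sits between two limits and gives no size. No direction can be drawn from them, and compound 3 itself sits only at a limit. The step from compound 3 to compound 4 is accordingly expected to be a number no higher from compound 3 to compound 4 (the limit leaves the size open), nothing the assay can resolve. Compound 4 is estimated at 200000 nM, within 60000 nM to 600000 nM, most probably reported once more only as a limit.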

Compound 4, half-maximal inhibitory concentration: > 200000 nM
Compound 4: only a limit was reported; the forecaster's own chance of this, stated with the estimate: 85%; the middle value lies on the limit itself.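

In this assay, among the compounds shown here, compound 4 gives > 200000 nM, a limit and not a number, so no step from compound 1, compound 2 or compound 3 to compound 4 can be read. The compounds shown leave open whether the amine on the shared core changes inhibition at all, and how the four amines compare, because all end at one ceiling: the limit of > 200000 nM in this assay, at which 4 of the 4 values shown sit.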